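The compounds below may be only part of what the source reports. "The series", "measured", "known", "first", "only" and "open" are said of these compounds alone.

Compound 1, `CC(C)(C)n1ncc(OCc2nnc(-c3ccc(F)cc3)o2)c(Cl)c1=O`: in a physicochemical assay for lipophilicity (on this read-out lower numbers stand for lower lipophilicity and higher numbers for higher lipophilicity), compound 1 gives 2.69.
Compound 2, `COc1ccc(-c2nnc(COc3cnn(C(C)(C)C)c(=O)c3Cl)o2)cc1`: compound 2 gives 3.52.
Compound 3, `CC(C)(C)n1ncc(OCc2nnc(-c3cccc(F)c3)o2)c(Cl)c1=O`: compound 3 gives 2.69.

Compound 3 sits together with compound 1 at the bottom of these three numbers: no change at the digits printed from compound 1 to compound 3 (within the scatter), so the two are level in this assay. Compound 2 stands apart from both, since a number 0.83 log units higher from compound 1 to compound 2 (beyond the scatter) and a number 0.83 log units lower from compound 2 to compound 3 (beyond the scatter).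

Compound 4, `CC(C)(C)n1ncc(OCc2nnc(-c3ccc(Cl)cc3)o2)c(Cl)c1=O`, has not yet been measured. Compared with compound 3 it carries 4-chlorophenyl in place of 3-fluorophenyl on an aromatic carbon. Two kinds of measured step bear on this. Moving the fluorine from one position of the phenyl ring to another left the value unchanged, as no change at the digits printed from compound 1 to compound 3 (within the scatter) shows. Exchanging the fluorine for a methoxy group, however, moved it: a number 0.83 log units higher from compound 1 to compound 2 (beyond the scatter). Within the data shown here, no measured pair here swaps a fluorine for a chlorine, so the size of the present step cannot be read off directly; the substituent exchange in compound 2 only shows that such a swap can shift the number beyond the scatter.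

Compound 4 is therefore expected to come out somewhat higher than compound 3 in this assay, with an estimated step of a number 0.51 log units higher from compound 3 to compound 4 (beyond the scatter). The estimate for compound 4 is 3.2, ranging from 2.9 to 3.5.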

Compound 4, partition coefficient: 3.09
Estimate against measurement, compound 4: 0.11 log units above; low and high end bracket the measured number.
By their numbers in this assay, from the lowest: compounds 1 and 3 (each within the scatter of the next); then compound 4; then compound 2.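

In this assay, exchanging one halogen for another on this aromatic carbon matters in a way that moving the fluorine did not: a number 0.40 log units higher from compound 1 to compound 4 (beyond the scatter) for the change from fluoro to chloro, and the comparison with the 3-fluorophenyl group gives the same size, a number 0.40 log units higher from compound 3 to compound 4 (beyond the scatter) in this case. The chloro group also does not reach the level of the methoxy group, with a number 0.43 log units lower from compound 2 to compound 4 (beyond the scatter) on that exchange, so among the groups at this place the 4-substituted phenyl series now has three separate levels, with fluoro lowest, chloro in the middle and methoxy highest. No measurement shown here offers an explanation for these differences, so the numbers describe the ranking without accounting for it.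

From the compounds shown here alone, it remains open whether a 3-chlorophenyl group would match the 4-chlorophenyl group, as the two fluorophenyl groups matched each other, since the level result for fluorine need not carry over to chlorine. The ranking also rests on just three substituents, so where an amine, a carboxylic acid or a longer chain such as butoxy on the phenyl ring would fall on this scale cannot be told from these compounds.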